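The source may report more compounds than this note shows. Statements on the series, on what has been measured and on what is new or still open speak of the compounds shown alone.

The measured compounds:
Compound 1, `O=C(O)CCc1ccc(OCc2ncc(-c3cccc(F)c3)o2)cc1`, gives 1070 nM in a functional assay on CHO cells for agonist activity at Free fatty acid receptor 1 (Homo sapiens), read by FLIPR and calcium flux, in the presence of a further agent that is not named here; on this read-out higher numbers stand for an effect only at larger amounts of compound and lower numbers for an effect already at smaller amounts.
Compound 2, `CC(Oc1ccc(CCC(=O)O)cc1)c1nc(-c2ccccc2)no1`, gives 2390 nM in this assay.
Compound 3, `CCc1ccc(-c2noc(COc3ccc(CCC(=O)O)cc3)n2)cc1`, gives 210 nM in this assay.

Of these three, compound 3 shows the lowest number, and its distance to compound 1 as well as to compound 2 lies beyond the usual scatter of repeated measurements, so it is the most potent compound of the measured set. Compound 4, `O=C(O)CCc1ccc(OCc2nc(-c3cccs3)no2)cc1`, has not yet been measured. It differs from compound 3 in one place: thiophen-2-yl in place of 4-ethylphenyl on an aromatic carbon. Within the data shown here, no two measured compounds differ from each other in a single place, so there is no measured step to lean on; compound 1 and compound 2 each differ from compound 3 in several places at once, and their values show only that other end groups on the shared core have gone along with larger numbers. The change takes away a ring with more heavy atoms and an ethyl chain and puts in a ring with fewer heavy atoms. The expected step, a 3.3-fold higher number from compound 3 to compound 4 (0.52 log units; beyond the scatter), is toward a larger number and beyond the scatter. Compound 4 is therefore estimated to give about 700 nM, with a range from 250 nM to 2000 nM.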

Compound 4, half-maximal effective concentration: 2570 nM
For compound 4 the middle estimate is 3.7-fold (0.56 log units) below the measured one; measured number outside the range, above it.
By their numbers in this assay, from the lowest: compound 3; then compound 1; then compounds 2 and 4 (each within the scatter of the next).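

At the aromatic carbon between two ring nitrogen atoms, the end group strongly affects the result: in this assay, putting thiophen-2-yl in place of 4-ethylphenyl gives a 12-fold higher number from compound 3 to compound 4 (1.09 log units; beyond the scatter), a large step. Among these compounds, compound 1 and compound 2 could not show this, since each differs from compound 3 in several places at once, whereas here only one group changes while the rest of the molecule stays the same. An aromatic ring at this position is therefore not enough to keep the low number of compound 3, but nothing shown here explains the size of the step, whether it comes from the ring size, the sulfur atom or the missing ethyl chain.

Among the compounds shown here, the single change replaces both the ring and its ethyl chain, so it remains open whether a plain phenyl group or an ethyl-bearing thiophene would give a number closer to that of compound 3 or that of compound 4. On these data alone, it is also open how a 4-propylphenyl group or a pyridine ring would behave at the same position.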